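Alkoxy in place of methylsulfonyl in the imidazoline series

This account rests on a few compounds, and the source may have more. Where it says the series, first, only, none or still open, it means among the compounds named here.

Three compounds of this series have been run in an assay on CHO cells for displacement of a labelled ligand from Alpha-2B adrenergic receptor (Homo sapiens); a higher number here means a weaker inhibitor, a lower number a stronger inhibitor. Compound 1 `CC(C)Oc1ccccc1OC(C)C1=NCCN1` gives 1580 nM. Compound 2 `COc1ccccc1OC(C)C1=NCCN1` gives 871 nM. Compound 3 `CC(Oc1ccccc1S(C)(=O)=O)C1=NCCN1` gives 51300 nM, the highest number of the three; the step of a 32-fold higher number from compound 1 to compound 3 (1.51 log units; beyond the scatter) and the step of a 59-fold higher number from compound 2 to compound 3 (1.77 log units; beyond the scatter) are both large, while the step of a 1.8-fold lower number from compound 1 to compound 2 (0.26 log units; within the scatter) stays within the scatter.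

Compound 4 `CCOc1ccccc1OC(C)C1=NCCN1` is not yet measured. Compared with compound 3 the change is ethoxy in place of methylsulfonyl on an aromatic carbon. The two steps that bear on it are the reverse of those already seen: both alkoxy groups at this carbon gave far lower numbers than methylsulfonyl, and the two alkoxy groups differed from each other only within the scatter. An ethoxy group sits in size between those two, so a large drop in the number, of about the same size as those two steps, is expected. The step of a 47-fold lower number from compound 3 to compound 4 (1.67 log units; beyond the scatter) is the estimate that follows. For compound 4 the expected value is 1100 nM, with a range from 450 nM to 2800 nM.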

Compound 4, inhibition constant: 1320 nM
Compound 4: middle estimate off by 1.2-fold (0.08 log units), on the low side; low and high end bracket the measured number.
By their numbers in this assay, from the lowest: compounds 2, 4 and 1 (each within the scatter of the next); then compound 3.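

In this assay a third alkoxy group at this aromatic carbon parts sharply from methylsulfonyl (a 39-fold lower number from compound 3 to compound 4 (1.59 log units; beyond the scatter)), so the large gap now holds for methoxy, ethoxy and isopropoxy alike. Among the alkoxy groups, the size of the group on the oxygen shows no readable effect across this short run, with ethoxy within the scatter of both neighbours in the set (a 1.5-fold higher number from compound 2 to compound 4 (0.18 log units; within the scatter); a 1.2-fold lower number from compound 1 to compound 4 (0.08 log units; within the scatter)). No measurement here explains why methylsulfonyl stands so far from the alkoxy groups.

From the compounds shown here alone, whether a longer chain such as butoxy stays level with compound 1, compound 2 and compound 4 remains open. Also open, going by these compounds, is where a hydroxyl, an amine or a bare hydrogen on this carbon would fall relative to the alkoxy groups and compound 3.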